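The source may report more compounds than this note shows. Statements on the series, on what has been measured and on what is new or still open speak of the compounds shown alone.

Of the compounds shown here, three that share one core have been tested in an ADME assay on HepG2 2.2.15 cells (Homo sapiens) for cytotoxicity, read by MTT assay, with a stated time of 9 days; a lower number here means that less compound is tolerated, a higher number that more compound is tolerated. Compound 1, `CCOC(=O)c1cc2c(CN(C)C)c(O)c(OC)cc2nc1CSc1ccc(F)cc1`, gives 120 uM. Compound 3, `CCOC(=O)c1cc2c(Cn3ccnc3)c(O)c(OC)cc2nc1CSc1ccc(F)c(F)c1`, gives 133 uM, and compound 2, `CCOC(=O)c1cc2c(CN3CCCC3)c(O)c(OC)cc2nc1C[S+]([O-])c1ccc(F)c(F)c1`, gives 16.5 uM. Among these three numbers compound 1 stands second highest; it lies closest to compound 3, and the two are within the usual scatter of each other, so no order between them can be read. The gap from compound 1 to compound 2 is the larger one and lies beyond the scatter.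

Compound 4, `CCOC(=O)c1cc2c(Cn3ccnc3C)c(O)c(OC)cc2nc1CSc1ccc(F)cc1`, has not yet been tested. It differs from compound 1 in one place: 2-methyl-1H-imidazol-1-yl in place of dimethylamino on a saturated chain carbon bound to an aromatic carbon. Compound 3 already carries an imidazolyl group on the same saturated chain carbon and sits within the scatter of compound 1, which gives a reason to expect little movement here. The expected step of a 1.0-fold higher number from compound 1 to compound 4 (0.02 log units; within the scatter) is none beyond the scatter, in either direction. Compound 4 is therefore estimated at 125 uM, with a likely range from 60 uM to 250 uM.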

Compound 4, half-maximal toxic concentration: 78.5 uM
For compound 4 the middle estimate is 1.6-fold (0.20 log units) above the measured one; low and high end bracket the measured number.
By their numbers in this assay, from the lowest: compound 2; then compounds 4, 1 and 3 (each within the scatter of the next).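

Going by these compounds alone, this is the first comparison in which only the group on the saturated chain carbon changes, because compounds 1, 2 and 3 all differ from each other in more than one place. In this assay, replacing dimethylamino with 2-methyl-1H-imidazol-1-yl gives a 1.5-fold lower number from compound 1 to compound 4 (0.18 log units; within the scatter), so this exchange of an open-chain group for a five-membered aromatic ring produces no readable change in tolerated concentration. Nothing available explains this result.

The compounds shown leave open whether other groups at this carbon, such as morpholine or piperazine, would also stay within the scatter of compound 1. They also do not separate the contribution of the methyl on the imidazole ring, since no matching compound without that methyl is shown.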